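Amide nitrogen substituents in a cell-growth series

This account rests on a few compounds, and the source may have more. Where it says the series, first, only, none or still open, it means among the compounds named here.

Compound 1 `CC1=C(/C=C/C(C)=C/C=C/C(C)=C\C(=O)NCc2cccc(F)c2)C(C)(C)CCC1n1ccnc1` gives 3090 nM in a functional assay on MDA-MB-468 cells (Homo sapiens) for inhibition, read by MTT assay; a lower number here means a stronger inhibitor of growth, a higher number a weaker inhibitor of growth. Compound 2 `CC1=C(/C=C/C(C)=C/C=C/C(C)=C\C(=O)Nc2cccc(F)c2)C(C)(C)CCC1n1ccnc1` gives 6760 nM. Compound 3 `CC1=C(/C=C/C(C)=C/C=C/C(C)=C\C(=O)NCc2ccc(O)cc2)C(C)(C)CCC1n1ccnc1` gives 2700 nM.

Compound 3 shows the lowest number of the three, but only a 2.5-fold lower number from compound 2 to compound 3 (0.40 log units; beyond the scatter) lies beyond the scatter, whereas a 1.1-fold lower number from compound 1 to compound 3 (0.06 log units; within the scatter) does not, so compound 3 and compound 1 cannot be ordered.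

Compound 4 `CC1=C(/C=C/C(C)=C/C=C/C(C)=C\C(=O)Nc2ccccc2O)C(C)(C)CCC1n1ccnc1` differs from compound 3 as 2-hydroxyphenyl in place of 4-hydroxybenzyl on an amide-type nitrogen. The bearing step is a 2.2-fold higher number from compound 1 to compound 2 (0.34 log units; beyond the scatter), where a 3-fluorophenyl replaced a 3-fluorobenzyl on the amide-type nitrogen; the reverse kind of change appears in a 2.5-fold lower number from compound 2 to compound 3 (0.40 log units; beyond the scatter). Both point the same way: removing the saturated chain carbon between ring and nitrogen raised the number modestly. A step of similar size is therefore expected, a 2.2-fold higher number from compound 3 to compound 4 (0.35 log units; beyond the scatter). Compound 4 is estimated at 6000 nM, in the range 3000 nM to 12000 nM.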

Compound 4, concentration for 50% growth inhibition: 3030 nM
The estimate for compound 4 lay 2.0-fold (0.30 log units) above the measured number; low and high end bracket the measured number.
By their numbers in this assay, from the lowest: compounds 3, 4 and 1 (each within the scatter of the next); then compound 2.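

Removing the saturated chain carbon does not by itself raise the number: 2-hydroxyphenyl on the amide-type nitrogen stays level with 4-hydroxybenzyl (a 1.1-fold higher number from compound 3 to compound 4 (0.05 log units; within the scatter)) and with 3-fluorobenzyl (a 1.0-fold lower number from compound 1 to compound 4 (0.01 log units; within the scatter)), so compound 4 goes against the rise seen with compound 2. With the ring bound directly to that nitrogen, the ring substituent now matters, as 2-hydroxyphenyl in place of 3-fluorophenyl gives a modest step (a 2.2-fold lower number from compound 2 to compound 4 (0.35 log units; beyond the scatter)). No measured evidence explains this result.

As far as these compounds go, whether the hydroxy group itself or its place on the ring drives that step remains open. Also open, from the compounds shown here alone, is how an amine or carboxylic acid on the ring, or a longer chain on the nitrogen, would read.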